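The source may report more compounds than this note shows. Statements on the series, on what has been measured and on what is new or still open speak of the compounds shown alone.

Among the compounds with values here, in a functional assay on A549 cells (Homo sapiens) for inhibition, read by sulforhodamine B assay, with a stated time of 48 h (on this read-out lower numbers stand for stronger inhibition of growth and higher numbers for weaker inhibition of growth), compound 2 (`COc1ccc(/C=C/C(=O)C(=Cc2cc(OC)c(OC)c(OC)c2)C(=O)/C=C/c2ccc(OC)c(OC)c2)cc1OC`) gives 230 nM, the lowest of the three numbers so far. Compound 3 (`COc1ccc(C=C(C(=O)/C=C/c2cc(OC)c(OC)c(OC)c2)C(=O)/C=C/c2cc(OC)c(OC)c(OC)c2)cc1OC`) gives 370 nM, which lies within the usual scatter of compound 2. Compound 1 (`COc1ccc(/C=C/C(=O)/C=C/c2cc(OC)c(OC)c(OC)c2)cc1OC`) gives 1210 nM, and its gap to compound 2 lies beyond that scatter. Compound 4 (`COc1ccc(OC)c(C=C(C(=O)/C=C/c2ccc(OC)c(OC)c2)C(=O)/C=C/c2ccc(OC)c(OC)c2)c1`) has not yet been measured. Compared with compound 2, it has 2,5-dimethoxyphenyl in place of 3,4,5-trimethoxyphenyl on a double-bonded chain carbon bound to a double-bonded chain carbon. Within the data shown here, no measured pair shows this change alone, so the expectation is loose. A small rise within the scatter is expected, a 1.5-fold higher number from compound 2 to compound 4 (0.17 log units; within the scatter). For compound 4 the estimated value is 340 nM, with an expected range of 120 nM to 950 nM.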

Compound 4, concentration for 50% growth inhibition: 530 nM
Beside the measured number, compound 4's estimate is 1.6-fold (0.19 log units) below it; the range from low to high includes it.
By their numbers in this assay, from the lowest: compounds 2, 3 and 4 (each within the scatter of the next, the first and the last beyond it); then compound 1.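

Placing 2,5-dimethoxyphenyl in place of 3,4,5-trimethoxyphenyl on a double-bonded chain carbon bound to a double-bonded chain carbon gives a 2.3-fold higher number from compound 2 to compound 4 (0.36 log units; beyond the scatter) in this assay. Within the data shown here, this is the first single change that can be read at this position, and it shows that the choice of aryl group here affects growth inhibition, though only modestly. The swap alters the number and the placing of the methoxy groups together, so the two effects cannot be separated.

As far as these compounds go, whether an unsubstituted phenyl ring, or a phenyl ring carrying an amine or a carboxylic acid, would be tolerated at this carbon remains open. No measurement here gives a reason for this step.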